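The source may hold more compounds than are shown below. What is called first, only, known or untested is meant among the compounds shown, and "the series" means these compounds.

Working notes on the series.

Compound 1 `O=C(Nc1cccc(/C=C/C(=O)c2nc3ccccc3[nH]2)c1)c1ccccc1` carries an unsubstituted benzamide on the shared core; in a functional assay on MCF7 cells (Homo sapiens) for antiproliferative activity, read by MTT assay, with a stated time of 48 h (on this read-out lower numbers stand for stronger inhibition and higher numbers for weaker inhibition), compound 1 gives 11200 nM. Compound 2 `O=C(Nc1cccc(/C=C/C(=O)c2nc3ccccc3[nH]2)c1)c1cccc(C(F)(F)F)c1` differs from it only by trifluoromethyl in place of hydrogen on an aromatic carbon, and in this assay compound 2 gives 21500 nM. Going by the values given here, the one measured step, a 1.9-fold higher number from compound 1 to compound 2 (0.28 log units; within the scatter), therefore shows no change that can be read as real. Among the compounds with values here, on the two numbers so far, compound 2 stands with the highest value, its nearest neighbour being compound 1, the two lying within the scatter of each other.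

Compound 3 `COc1ccc(C(=O)Nc2cccc(/C=C/C(=O)c3nc4ccccc4[nH]3)c2)cc1` is the next compound, not yet measured. The change from compound 2 to compound 3 is 4-methoxyphenyl in place of 3-(trifluoromethyl)phenyl on a carbonyl carbon. Within the data shown here, the only step that bears on this change is a 1.9-fold higher number from compound 1 to compound 2 (0.28 log units; within the scatter), which did not move the number beyond the scatter; no measured step informs on a methoxy group. Compound 3 is expected in this assay to land near the two measured numbers, at an estimated 12000 nM with a range from 4000 nM to 36000 nM. The step that this estimate implies, a 1.8-fold lower number from compound 2 to compound 3 (0.25 log units; within the scatter), is expected to stay within the scatter.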

Compound 3, half-maximal inhibitory concentration: 20100 nM
The estimate for compound 3 lay 1.7-fold (0.22 log units) below the measured number; the range from low to high includes it.
By their numbers in this assay, from the lowest: compounds 1, 3 and 2 (each within the scatter of the next).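

On the carbonyl carbon whose other neighbour is the amide-type nitrogen, 4-methoxyphenyl in place of 3-(trifluoromethyl)phenyl gives, in this assay, a 1.1-fold lower number from compound 2 to compound 3 (0.03 log units; within the scatter), so exchanging one substituted phenyl for the other leaves no difference that can be read. Methoxy in place of hydrogen on an aromatic carbon gives a 1.8-fold higher number from compound 1 to compound 3 (0.25 log units; within the scatter), so this second substituent, like trifluoromethyl before it, does not separate from the unsubstituted benzamide of compound 1, and all three aryl groups at this position now lie within the scatter of one another. No measurement is available that would explain this flat picture.

Open, from the compounds shown here alone, is whether an amine or a carboxylic acid on this phenyl ring, or a longer alkoxy chain in place of methoxy, would move the number beyond the scatter. Also open, going by these compounds, is whether a group without an aromatic ring on this carbonyl carbon would leave the number within the scatter of the three aryl compounds.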